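The source may hold more compounds than are shown below. What is called first, only, known or untested is meant among the compounds shown, and "the series" means these compounds.

Measured in a functional assay for inhibition, with Homo sapiens as the target; on this read-out lower numbers stand for tighter binding and higher numbers for weaker binding:
- Compound 1 `CC(C)(Oc1ccc(F)cc1)C1OCC(C/C=C\CCC(=O)O)C(c2cccnc2)O1`: 120 nM
- Compound 2 `Cc1ccc(OC(C)(C)C2OCC(C/C=C\CCC(=O)O)C(c3cccnc3)O2)cc1`: 631 nM
- Compound 3 `COc1ccccc1OC(C)(C)C1OCC(C/C=C\CCC(=O)O)C(c2cccnc2)O1`: 224 nM

The values place compound 3 close to one neighbour and clearly apart from the other: a 1.9-fold higher number from compound 1 to compound 3 (0.27 log units; within the scatter), and a 2.8-fold lower number from compound 2 to compound 3 (0.45 log units; beyond the scatter).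

Compound 4 `COc1ccc(OC(C)(C)C2OCC(C/C=C\CCC(=O)O)C(c3cccnc3)O2)c([N+](=O)[O-])c1` carries 4-methoxy-2-nitrophenyl in place of 2-methoxyphenyl on an oxygen on a saturated carbon.

All three measured steps change the same aryl group, and the largest is a 5.3-fold higher number from compound 1 to compound 2 (0.72 log units; beyond the scatter). These steps stay modest, but none involves a nitro group, so they give no direction for this change. The expected step in this assay is therefore none beyond the scatter: a 1.1-fold higher number from compound 3 to compound 4 (0.05 log units; within the scatter).

The estimated value for compound 4 is 250 nM, with an expected range of 80 nM to 800 nM.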

Compound 4, dissociation constant: 6.17 nM
Compound 4: middle estimate off by 41-fold (1.61 log units), on the high side; measured number below the stated range.
By their numbers in this assay, from the lowest: compound 4; then compounds 1 and 3 (each within the scatter of the next); then compound 2.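

In this assay this position on the oxygen proves far more sensitive than the earlier aryl groups suggested: 4-methoxy-2-nitrophenyl in place of 2-methoxyphenyl gives a 36-fold lower number from compound 3 to compound 4 (1.56 log units; beyond the scatter) and this step is larger than any seen before. The new group also stands apart from the other two aryl groups, with a 100-fold lower number from compound 2 to compound 4 (2.01 log units; beyond the scatter) and a 19-fold lower number from compound 1 to compound 4 (1.29 log units; beyond the scatter) as its steps. No measurement shown gives a reason for these large drops.

The change brings in the nitro group and alters the methoxy placement at once, and the compounds shown do not separate the two. On these data alone, whether an amine or a nitrile in place of the nitro group would keep the number this low stays open.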